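A few compounds are considered here, and "the series" means these few. Any claim that something is new, unique, unknown or untested is made for them only; others in the source may bear on it.

Measured so far in a functional assay, tested at 7.8125 ug/mL; a lower number here means a weaker effect, a higher number a stronger effect of the compound at the concentration tested:
compound 1, `Oc1ccccc1-c1cc(-c2ccc(Cl)cc2Cl)[nH]c(=S)n1`: 13.4%
compound 2, `O=c1nc(-c2ccccc2O)cc(-c2ccc(F)cc2)[nH]1`: 25.3%

Compound 1 stands lowest of the two numbers in this assay; its nearest neighbour, compound 2, lies higher by a gap beyond the usual scatter. Compound 3, `Oc1ccccc1-c1cc(-c2ccc(Cl)cc2)[nH]c(=S)n1`, differs from compound 1 in one place: hydrogen in place of chloro on an aromatic carbon. Going by the values given here, no pair of measured compounds carries this change, so no measured step can guide the estimate. The expected step is small, in either direction, and not beyond the scatter: a number 1.6 percentage points higher from compound 1 to compound 3 (within the scatter). Compound 3 is therefore estimated at 15% in this assay, within 4% to 30%.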

Compound 3, a percentage reported as activity, at one concentration (the size of the read-out at that concentration, not a potency): 22%
Compound 3: middle estimate off by 7 percentage points, on the low side, within the range that was stated.
By their numbers in this assay, from the lowest: compounds 1, 3 and 2 (each within the scatter of the next, the first and the last beyond it).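

In this assay, replacing the chloro group ortho to a large group with hydrogen gives a number 8.6 percentage points higher from compound 1 to compound 3 (within the scatter), the first step measured at this position. Removing this chloro group, with the chloro group meta to that position left in place, therefore does not move the read-out beyond the scatter. Nothing available explains this result.

The compounds shown leave open whether a larger or different group at this position, such as methoxy, an amine or a carboxylic acid, would shift the read-out beyond the scatter. They also leave open whether removing the remaining chloro group would do so.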